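Fluoro for ethyl on the urea aryl ring

The compounds below may be only part of what the source reports. "The series", "measured", "known", "first", "only" and "open" are said of these compounds alone.

Three ureas sharing one core have been measured in an ADME assay on the whole organism with Oryza sativa as the target, tested at 1 uM; a lower number here means a stronger effect, a higher number a weaker effect of the compound at the concentration tested. Compound 1 `CCc1ccc(NC(=O)N[C@H](C)c2ccccc2)cc1` gives 47%. Compound 2 `CCc1ccc(NC(=O)N[C@@H](C)c2ccccc2)cc1` gives 95%, and compound 3 `CCOC(=O)c1cccc(NC(=O)N[C@@H](C)c2ccccc2)c1` gives 99%. Going by the values given here, the only step between neighbours is a number 48 percentage points higher from compound 1 to compound 2 (beyond the scatter), a shift that rests on (the fact that compounds 1 and 2 differ only in the configuration as drawn). Among the three numbers compound 2 sits near the top: its value and that of compound 3 lie within the scatter of each other, while compound 1 lies well beyond it.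

The next compound, compound 4 `C[C@H](NC(=O)Nc1ccc(F)cc1)c1ccccc1`, is not yet measured. It differs from compound 2 in one place: fluoro in place of ethyl on an aromatic carbon. Among the compounds with values here, no measured step touches this kind of change; the one step known alters configuration only, and compound 2 and compound 3, which carry different groups on the aryl ring, show values within the scatter of each other. So no step beyond the scatter is expected in this assay in either direction. The step expected from this change is a number 5 percentage points lower from compound 2 to compound 4 (within the scatter). Compound 4 is therefore estimated at 90%, with a range from 65% to 100%, because compound 2 gives 95% and the change gives no ground to move far from it.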

Compound 4, a percentage reported as activity, at one concentration (the size of the read-out at that concentration, not a potency): 97%
Compound 4: middle estimate off by 7 percentage points, on the low side; low and high end bracket the measured number.
By their numbers in this assay, from the lowest: compound 1; then compounds 2, 4 and 3 (each within the scatter of the next).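

In this assay, going by these compounds alone, the replacement of ethyl by fluoro on an aromatic carbon, para to a large group, gives a number 2 percentage points higher from compound 2 to compound 4 (within the scatter), the first measured step for any change of group at this place. Going from 2 heavy atoms of carbon to a single fluorine atom therefore does not separate the two compounds in this read-out, at least in the configuration that compound 2 and compound 4 share. The only step beyond the scatter among the compounds shown remains a number 48 percentage points higher from compound 1 to compound 2 (beyond the scatter), and it rests on stereochemistry rather than on a ring group: the fact that compounds 1 and 2 differ only in the configuration as drawn

The compounds shown leave open whether a group at this place matters in the configuration drawn for compound 1, which gives 47%, as every ring group other than ethyl among them sits in the opposite configuration. Also open, on these data alone, is how an amine, a carboxylic acid or a longer chain at this same place would read in this assay, and whether any of them would give a step beyond the scatter.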